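The compounds below may be only part of what the source reports. "The series", "measured", "known", "first", "only" and "open" are said of these compounds alone.

Measured in a functional assay on PC-3 cells (Homo sapiens) for antiproliferative activity, read by MTT assay, with a stated time of 48 h; on this read-out lower numbers stand for stronger inhibition and higher numbers for weaker inhibition:
- compound 1 `C#CC(C)OC(=O)c1ccc(C(CC)(CC)c2ccc(OCCC(O)(CC)CC)c(C)c2)n1CC`: 14800 nM
- compound 2 `CCn1c(C(=O)Nc2cccc(C(F)(F)F)c2)ccc1C(CC)(CC)c1ccc(OCCC(O)(CC)CC)c(C)c1`: 23800 nM
- compound 3 `CCC(C)C(NC(=O)c1ccc(C(CC)(CC)c2ccc(OCCC(O)(CC)CC)c(C)c2)n1CC)C(=O)O`: 13800 nM

These three compounds share a core and differ only in the group on the carbonyl carbon. Compound 3, at 13800 nM, sits within the scatter of both others, as a 1.1-fold lower number from compound 1 to compound 3 (0.03 log units; within the scatter) and a 1.7-fold lower number from compound 2 to compound 3 (0.24 log units; within the scatter) show.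

Compound 4 `CCn1c(C(=O)NC(C)C(=O)O)ccc1C(CC)(CC)c1ccc(OCCC(O)(CC)CC)c(C)c1` changes compound 3 in one place: methyl in place of sec-butyl on a saturated chain carbon bound to an amide-type nitrogen and a carbonyl carbon.

Among the compounds with values here, no measured pair makes this exact swap, so the evidence is indirect. Larger exchanges of the whole group on the carbonyl carbon gave only small steps, a 1.1-fold lower number from compound 1 to compound 3 (0.03 log units; within the scatter), a 1.7-fold lower number from compound 2 to compound 3 (0.24 log units; within the scatter) and a 1.6-fold higher number from compound 1 to compound 2 (0.21 log units; within the scatter), all within the scatter. No step beyond the scatter is therefore expected in this assay, though this rests on just three compounds.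

The expected change is a 1.2-fold higher number from compound 3 to compound 4 (0.06 log units; within the scatter).

Compound 4 is estimated at 16000 nM, with an expected range from 8000 nM to 32000 nM.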

Compound 4, half-maximal inhibitory concentration: 11700 nM
Beside the measured number, compound 4's estimate is 1.4-fold (0.14 log units) above it; the range from low to high includes it.
By their numbers in this assay, from the lowest: compounds 4, 3, 1 and 2 (each within the scatter of the next, the first and the last beyond it).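

Replacing sec-butyl with methyl on a saturated chain carbon bound to an amide-type nitrogen and a carbonyl carbon gives a 1.2-fold lower number from compound 3 to compound 4 (0.07 log units; within the scatter) in this assay, so removing most of this side chain while keeping the carboxylic acid leaves the number unchanged within the scatter. Within the data shown here, the exchange of the whole group gives a 2.0-fold lower number from compound 2 to compound 4 (0.31 log units; beyond the scatter) and is the first step here to pass the scatter, though only modestly, while a 1.3-fold lower number from compound 1 to compound 4 (0.10 log units; within the scatter) does not pass it. No measurement here explains these steps.

The compounds shown leave open whether a plain hydrogen, a benzyl group or a chain ending in an amine on this same carbon would shift the number further. They also leave open whether the same change from sec-butyl to methyl would behave alike with a methyl ester in place of the carboxylic acid.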